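Solubility in the benzylamine series: furan to methoxyphenol

A few compounds are considered here, and "the series" means these few. Any claim that something is new, unique, unknown or untested is made for them only; others in the source may bear on it.

Compound 3 `c1coc(CNCCCNc2ccnc3cc(-c4cccc5ccccc45)ccc23)c1` gives 32000 nM in a physicochemical assay for solubility, with a stated time of 18 h, at pH 7.4 (on this read-out higher numbers stand for higher solubility and lower numbers for lower solubility), the highest of the three measured numbers; compound 1 `COc1cccc(CNCCCNc2ccnc3cc(C4CCCCC4)ccc23)c1O` gives 4200 nM and compound 2 `COc1cccc(CNCCCNc2ccnc3cc(CCC(C)C)ccc23)c1O` gives 4200 nM, both well below it. For the measured compounds named here, the one measured step, no change at the digits printed from compound 1 to compound 2 (within the scatter), concerns a different part of the molecule and does not bear on the present change. Compound 4 `COc1cccc(CNCCCNc2ccnc3cc(-c4cccc5ccccc45)ccc23)c1O` differs from compound 3 by 2-hydroxy-3-methoxyphenyl in place of furan-2-yl on a saturated chain carbon bound to an amine nitrogen. Compounds 1 and 2 carry the same 2-hydroxy-3-methoxybenzyl group and sit far lower than compound 3, so a drop is expected, though the remaining difference leaves the size uncertain. Compound 4 is therefore estimated at 6000 nM, within 2000 nM to 20000 nM, an expected step of a 5.3-fold lower number from compound 3 to compound 4 (0.73 log units; beyond the scatter).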

Compound 4, solubility: 32000 nM
Compound 4: the middle estimate sits 5.3-fold (0.73 log units) below what was measured; measured number above the stated range.
By their numbers in this assay, from the lowest: compounds 1 and 2 (each within the scatter of the next); then compounds 3 and 4 (each within the scatter of the next).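

In this assay, no change at the digits printed from compound 3 to compound 4 (within the scatter), so with naphthalen-1-yl on the aromatic carbon, furan-2-yl and 2-hydroxy-3-methoxyphenyl read alike on a saturated chain carbon bound to an amine nitrogen. With the 2-hydroxy-3-methoxybenzyl group held constant, a 7.6-fold higher number from compound 2 to compound 4 (0.88 log units; beyond the scatter) and a 7.6-fold higher number from compound 1 to compound 4 (0.88 log units; beyond the scatter), so the gap seen earlier goes with the group on the aromatic carbon, not the benzyl change. No supporting measurement accounts for this. Still open, going by these compounds, is whether a pyridine ring or a carboxylic acid in place of furan-2-yl would read the same. Also open, on these data alone, is whether furan-2-yl matches the benzyl group with cyclohexyl on the aromatic carbon.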